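Swapping a Side Group on the Shared Core

The source may hold more compounds than are shown below. What is called first, only, known or untested is meant among the compounds shown, and "the series" means these compounds.

In an ADME assay on HOS cells (Homo sapiens) for cytotoxicity (on this read-out higher numbers stand for lower toxicity in this test and lower numbers for higher toxicity in this test), compound 1 `CN(Cc1nc2ccccc2n1CCCNC(=O)C(F)(F)F)C1CCCc2cccnc21` gives 10400 nM and compound 3 `CN(C)CCCc1cccc2nc(CN(C)C3CCCc4cccnc43)[nH]c12` gives 7500 nM, two values within the usual scatter of each other. Compound 2 `CN(Cc1nc2cccc(CN)c2[nH]1)C1CCCc2cccnc21` reads > 20000 nM, which is a limit of the assay and not a number.

Compound 4 `CN1CCN(c2cccc3nc(CN(C)C4CCCc5cccnc54)[nH]c23)CC1` has not yet been measured. It carries 4-methylpiperazin-1-yl in place of 3-(dimethylamino)propyl on an aromatic carbon. Going by the values given here, the one measured step that bears on this change is an at least 2.6-fold lower number from compound 2 to compound 3 (0.42 log units; beyond the scatter). Among the compounds with values here, that step shows that altering the group at this place can move the number, but it is only a single example and it involves no ring. It therefore gives no firm direction for the new group, so no shift beyond the scatter is expected, and a modest rise is only a slight lean. The expected change is a 1.3-fold higher number from compound 3 to compound 4 (0.12 log units; within the scatter). For compound 4 the estimated value is 10000 nM, with an expected range from 4000 nM to 20000 nM.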

Compound 4, half-maximal cytotoxic concentration: 14000 nM
For compound 4 the middle estimate is 1.4-fold (0.15 log units) below the measured one; the range from low to high includes it.
By their numbers in this assay, from the lowest: compounds 3, 1 and 4 (each within the scatter of the next). At a limit, above all of these: compound 2.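

In this assay, a ring-bearing group on this aromatic carbon reads much like the open chain it replaces, with a 1.9-fold higher number from compound 3 to compound 4 (0.27 log units; within the scatter), so 4-methylpiperazin-1-yl and 3-(dimethylamino)propyl cannot be told apart at this place. Against aminomethyl at the same place, the comparison gives only an at least 1.4-fold lower number from compound 2 to compound 4 (0.15 log units; that floor lies within the scatter), so this change is not shown to move the number beyond the scatter. Compound 2 sits at a limit of the assay and not at a number: the limit of > 20000 nM in this assay, at which 1 of the 4 values shown sits.

On these data alone, all three groups compared here carry an amine nitrogen, so it remains open whether a group without one, such as a carboxylic acid or a plain phenyl ring, would read differently on this aromatic carbon. As far as these compounds go, how far the true gap between aminomethyl and 4-methylpiperazin-1-yl lies beyond its floor also stays unknown.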